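This account rests on a few compounds, and the source may have more. Where it says the series, first, only, none or still open, it means among the compounds named here.

Compound 1 (`COc1ccc(CN2CCC=C(CCC(=O)NO)C2=O)cc1`) gives 6890 nM here
Compound 2 (`O=C(CCC1=CCCN(Cc2ccc(Br)cc2)C1=O)NO`) gives 1720 nM here

In a functional assay on HCT-15 cells (Homo sapiens) for inhibition, read by sulforhodamine B assay (on this read-out lower numbers stand for stronger inhibition of growth and higher numbers for weaker inhibition of growth), compound 2 at 1720 nM holds the lower of the two numbers. Compound 3 (`O=C(CCC1=CCCN(Cc2ccc([N+](=O)[O-])cc2)C1=O)NO`) carries nitro in place of bromo on an aromatic carbon. For the measured compounds named here, one measured step touches that carbon, bromo in place of methoxy (a 4.0-fold lower number from compound 1 to compound 2 (0.60 log units; beyond the scatter)), and it was modest. Nitro itself has not been measured there, so that step gives only a rough scale. A small change toward a higher number, within the scatter, is expected (a 1.4-fold higher number from compound 2 to compound 3 (0.14 log units; within the scatter)). For compound 3 the estimated value is 2400 nM (expected range 800 nM to 7000 nM).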

Compound 3, concentration for 50% growth inhibition: > 10000 nM
Compound 3: a limit, no number (the forecaster's own chance of this, stated with the estimate: 3%); at least 4.1-fold (0.61 log units) between middle value and limit.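

In this assay, this aromatic carbon tolerates less than the earlier swap suggested, since changing the group there can cost more than that first step did: an at least 5.8-fold higher number from compound 2 to compound 3 (0.76 log units; beyond the scatter). As far as these compounds go, compound 3 gives > 10000 nM, which is a limit of the assay and not a number, so the full size of this step stays unknown. The comparison with methoxy gives an at least 1.4-fold higher number from compound 1 to compound 3 (0.16 log units; that floor lies within the scatter), which leaves nitro and methoxy unordered.

With only three groups shown on this carbon, it remains open how an amine, a chloro group or a carboxylic acid would read there.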